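Thiophene ring-position swap on the saturated ring carbon

The source may hold more compounds than are shown below. What is called first, only, known or untested is meant among the compounds shown, and "the series" means these compounds.

Measured so far:
compound 1 `COC(=O)C1=C(C)N(C)C(=O)NC1c1ccoc1`: 7%
compound 2 `COC(=O)C1=C(C)N(C)C(=O)NC1c1cccs1`: 17%

In an assay on membranes from HEK293 cells for displacement of a labelled ligand from adenosine receptor A2b (Homo sapiens), read by scintillation counting, with a stated time of 30 min, tested at 1 uM (a lower number here means less inhibition, a higher number more inhibition at the concentration tested (going by the name of the read-out)), compound 1 gives 7%. Compound 2 gives 17%. Of the two numbers, that of compound 2 is nominally the larger, but a number 10 percentage points higher from compound 1 to compound 2 (within the scatter) lies within the scatter, so the two compounds are not told apart.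

Compound 3 `COC(=O)C1=C(C)N(C)C(=O)NC1c1ccsc1` differs from compound 2 by thiophen-3-yl in place of thiophen-2-yl on a saturated ring carbon. Among the measured compounds shown here, the only step that bears on this change is the ring swap at the same carbon, a number 10 percentage points higher from compound 1 to compound 2 (within the scatter), which was within the scatter. No step beyond the scatter is therefore expected in this assay ; the expected change is a number 3 percentage points lower from compound 2 to compound 3 (within the scatter). Compound 3 is estimated at 14%, with a range from 2% to 30%.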

Compound 3, a percentage reported as inhibition, at one concentration (the size of the read-out at that concentration, not a potency): 26%
Compound 3: middle estimate off by 12 percentage points, on the low side; measured number inside the range.
By their numbers in this assay, from the lowest: compounds 1, 2 and 3 (each within the scatter of the next, the first and the last beyond it).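

In this assay the swap of thiophen-2-yl for thiophen-3-yl gives a number 9 percentage points higher from compound 2 to compound 3 (within the scatter) and so does not separate the two thiophenes. Thiophen-3-yl in place of furan-3-yl gives a number 19 percentage points higher from compound 1 to compound 3 (beyond the scatter) and is the only step so far to pass the scatter, though it is modest and read at a single concentration. Nothing at hand explains this step.

Still open, on these data alone, is whether a phenyl or a pyridyl group at this saturated ring carbon would raise the inhibition further. Also open, as far as these compounds go, is how a dimethylamino group on the thiophen-3-yl ring would read.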